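Swapping a Fluorophenyl for a Hydroxyphenyl on the Amine

The compounds below may be only part of what the source reports. "The series", "measured", "known", "first", "only" and "open" are said of these compounds alone.

Three compounds have been measured in a functional assay on MDA-MB-231 cells (Homo sapiens) for cytotoxicity, read by MTT assay, with a stated time of 48 h; on this read-out higher numbers stand for weaker inhibition and lower numbers for stronger inhibition:
- compound 1, `Fc1cccc(-c2nc(Nc3ccccc3)c3cc(F)ccc3n2)c1`, gives 47800 nM.
- compound 2, `Fc1ccc(Nc2nc(-c3cccc(F)c3)nc3ccc(F)cc23)cc1`, gives only the assay limit > 50000 nM.
- compound 3, `Fc1cccc(-c2nc(Nc3ccc(Br)cc3)c3cc(F)ccc3n2)c1`, gives only the assay limit > 50000 nM.

Compound 2 therefore stands at the assay limit, the point where the read-out stops reporting a number; (the limit of > 50000 nM in this assay, at which 2 of the 3 values shown sit). Compound 1 sits just below that point, and the step of an at least 1.0-fold higher number from compound 1 to compound 2 (0.01 log units; that floor lies within the scatter) lies within the usual scatter, so these two compounds cannot be told apart on the numbers. The step that the two limits leave unreadable from compound 2 to compound 3 gives no readable size because both ends are limits.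

Compound 4, `Oc1ccccc1Nc1nc(-c2cccc(F)c2)nc2ccc(F)cc12`, has not yet been measured. It differs from compound 2 in one place: 2-hydroxyphenyl in place of 4-fluorophenyl on a nitrogen on an aromatic ring. Going by the values given here, none of the measured steps changes this part of the molecule in the same way, so they only show that the shared core with a fluorophenyl or a bromophenyl on the amine gives weak inhibition. Among the compounds with values here, no step points to a gain, and a step of about the size an at least 1.1-fold lower number from compound 2 to compound 4 (0.07 log units; that floor lies within the scatter) is expected. Compound 4 is therefore estimated at 42000 nM, within a range from 12000 nM to 50000 nM, with a real chance that this assay again reports only a limit.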

Compound 4, half-maximal inhibitory concentration: > 50000 nM
Compound 4 ended at the assay's limit; the forecaster's own chance of this, stated with the estimate: 55%; middle value at least 1.1-fold (0.07 log units) from the limit.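

In this assay compound 4 gives only a limit, > 50000 nM, so a 2-hydroxyphenyl on the amine, which brings a hydrogen-bond donor and a hydrogen-bond acceptor that 4-fluorophenyl does not have, still gives no readable number. Adding a hydroxy group gives an at least 1.0-fold higher number from compound 1 to compound 4 (0.01 log units; that floor lies within the scatter), so this change, unlike the fluoro and bromo changes seen so far, adds a group with oxygen, yet it too cannot be told apart from hydrogen on the numbers. The steps to compound 4 from compound 2 and from compound 3 cannot be read, because every one of these compounds sits at the same limit: the limit of > 50000 nM in this assay, at which 3 of the 4 values shown sit.

Still open, on these data alone, is whether another group on the amine, such as an aminophenyl, a carboxylic acid on the phenyl ring or a longer chain in place of the ring, would give a clearly lower number than compound 1, which gives 47800 nM. Also open, as far as these compounds go, is whether compound 2, compound 3 and compound 4 differ from one another at all, since the limit hides any true values they may have.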